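Replacing the formyl hydrogen of compound 3

The source may hold more compounds than are shown below. What is called first, only, known or untested is meant among the compounds shown, and "the series" means these compounds.

Measured so far in a functional assay on HCT-15 cells (Homo sapiens); on this read-out lower numbers stand for an effect already at smaller amounts and higher numbers for an effect only at larger amounts of compound:
compound 1 `COc1cc(C2OC(c3ccc(N(C)C)cc3)=NN2C(C)=O)cc(OC)c1OC(C)=O` gives 78 uM
compound 2 `COc1ccc(C2OC(c3ccc(N(C)C)cc3)=NN2C(C)=O)cc1OC` gives 8.2 uM
compound 3 `COc1cc(C2OC(c3ccc(N(C)C)cc3)=NN2C=O)cc(OC)c1OC` gives 0.096 uM

Compound 3 has the lowest number of the three, clear of the scatter from compound 2, its nearest neighbour, and further still from compound 1. Compound 4 `COc1cc(C2OC(c3ccc(N(C)C)cc3)=NN2C(=O)CO)cc(OC)c1OC` follows from compound 3 with hydroxymethyl in place of hydrogen on a carbonyl carbon, a change that reads hydroxymethyl in place of hydrogen on a carbonyl carbon and turns formyl into (hydroxymethyl)carbonyl.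

Among the measured compounds shown here, no two measured compounds differ in one place only, so the size of this change in this assay has no direct measure. Compound 2 stands at 8.2 uM and compound 1 at 78 uM without the formyl group, but each also differs from compound 3 elsewhere, so they guide the direction only. The expected change is a 10-fold higher number from compound 3 to compound 4 (1.02 log units; beyond the scatter) toward a higher number, beyond the scatter. For compound 4 the estimated value is 1 uM with an expected range from 0.12 uM to 9 uM in this assay for now.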

Compound 4, concentration for half-maximal effect: 0.026 uM
The estimate for compound 4 lay 38-fold (1.59 log units) above the measured number, outside the stated range (below it).
By their numbers in this assay, from the lowest: compound 4; then compound 3; then compound 2; then compound 1.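

In this assay, among the compounds shown here, the carbonyl carbon on the amide-type nitrogen in a ring accepts hydroxymethyl in place of hydrogen, with a 3.7-fold lower number from compound 3 to compound 4 (0.57 log units; beyond the scatter) as the first step that changes one place only. The formyl hydrogen is therefore not required for the low number of compound 3, and this position tolerates a larger group with a modest gain. Nothing available explains the step.

The compounds shown leave open whether the step belongs to the oxygen or the carbon of hydroxymethyl, and how an aminomethyl group, a carboxylic acid or a longer hydroxyalkyl chain on this carbonyl carbon would read. Compound 1 and compound 2 carry an acetyl group here but also differ elsewhere, so they cannot settle this.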